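A stereochemical reversal on the shared core

This account rests on a few compounds, and the source may have more. Where it says the series, first, only, none or still open, it means among the compounds named here.

Compound 2 `CCCCSc1nsnc1[C@@H]1CN2CCC[C@H]1C2` stands in a functional assay on the whole organism with Mus musculus as the target (a higher number here means that more compound is needed for the effect, a lower number that less compound is needed), only at a limit of the assay: compound 2 gives > 3 mg/kg, which is a limit and not a number. Compound 1 `CCCCSc1nsnc1[C@H]1CN2CCC[C@H]1C2` likewise stands at a limit, as compound 1 gives > 1 mg/kg in this assay. The step that the two limits leave unreadable from compound 1 to compound 2 therefore cannot be sized; the evidence for it consists of the limit of > 1 mg/kg in this assay, at which 1 of the 2 values shown sits, for compound 1 and, separately, the limit of > 3 mg/kg in this assay, at which 1 of the 2 values shown sits, for compound 2, together with the fact that one of compounds 1 and 2 is drawn with a defined configuration and the other without, at the place where they differ. Compound 3 `CCCCSc1nsnc1[C@H]1CN2CCC[C@@H]1C2` has not yet been measured in this assay. Its difference from compound 2 is the two compounds have the same atoms and bonds; at least one stereo element is drawn with a configuration in one of them and without one in the other: 2 of 3 stereo elements differ; a stereocentre at a saturated ring carbon is drawn S in compound 2 and R in compound 3; a stereocentre at a saturated ring carbon is drawn R in compound 2 and S in compound 3. For the measured compounds named here, the only measured step turns one stereocentre at a saturated ring carbon and is unreadable, so no size can be carried over to a change at two such centres. The step from compound 2 to compound 3 in this assay is accordingly estimated without a readable precedent as a number no higher from compound 2 to compound 3 (the limit leaves the size open). Compound 3 is expected to give about 3 mg/kg, within a range from 0.5 mg/kg to 30 mg/kg, with a fair chance that only a limit is reported.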

Compound 3, dose for half-maximal effect: > 0.3 mg/kg
Compound 3: only a limit was reported; the forecaster's own chance of this, stated with the estimate: 60%; the middle value does not contradict the limit.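

Compound 3 gives > 0.3 mg/kg in this assay, which is a limit and not a number. Since compounds 1, 2 and 3 all stand at limits, none of the steps among them can be read. The compounds shown leave open how strongly the configuration at the saturated ring carbons affects the dose needed in this assay.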